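The source may report more compounds than this note shows. Statements on the series, on what has been measured and on what is new or still open speak of the compounds shown alone.

Of the compounds shown here, two sharing one core have been tested in an assay on membranes from HeLa cells for displacement of a labelled ligand from adenosine receptor A3 (Homo sapiens), read by scintillation counting, with a stated time of 180 min, tested at 1 uM; on this read-out lower numbers stand for less inhibition and higher numbers for more inhibition at the one concentration tested (going by the name of the read-out). Compound 1 `CC1=C(C(=O)C2CC2)C(c2ccco2)NC(=O)N1` gives 7%. Compound 2 `CC(=O)C1=C(C)NC(=O)NC1c1ccsc1`, in this assay, gives 1%, a number that sits within the scatter of compound 1, so the two cannot be told apart. Compound 3 `CC1=C(C(=O)C2CC2)C(c2ccsc2)NC(=O)N1` has not yet been measured; compared with compound 2 it carries cyclopropyl in place of methyl on a carbonyl carbon. Compound 1 already holds this cyclopropylcarbonyl group and shows no clear inhibition, so the expected step from compound 2 to compound 3 is a number 4 percentage points higher from compound 2 to compound 3 (within the scatter), nothing beyond the scatter. Compound 3 is therefore estimated at 5%, between -5% and 15%.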

Compound 3, a percentage reported as inhibition, at one concentration (the size of the read-out at that concentration, not a potency): 1%
Estimate against measurement, compound 3: 4 percentage points above; the range from low to high includes it.
By their numbers in this assay, from the lowest: compounds 2, 3 and 1 (each within the scatter of the next).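

In this assay, within the data shown here, cyclopropyl in place of methyl on a carbonyl carbon gives no change at the digits printed from compound 2 to compound 3 (within the scatter), the first direct reading of this change at this position. Thiophen-3-yl in place of furan-2-yl on a saturated ring carbon gives a number 6 percentage points lower from compound 1 to compound 3 (within the scatter), so neither change separates the compounds. Nothing measured here offers a reason for these results.

On these data alone, all three compounds sit within the scatter of one another, so it remains open whether either position can affect inhibition at all. An amine or a longer chain on that carbonyl carbon, or a phenyl ring on the saturated ring carbon, could speak to this.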